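A Smaller Heterocycle on the Sulfur of Compound 1

A few compounds are considered here, and "the series" means these few. Any claim that something is new, unique, unknown or untested is made for them only; others in the source may bear on it.

Compound 1 `O=C(CSc1nnnn1-c1ccccc1)N/N=c1/scc(-c2ccccc2)n1-c1ccccc1` gives the highest of three numbers: in an ADME assay on NIH3T3 cells (Mus musculus) for cytotoxicity, read by MTT assay, with a stated time of 24 h (on this read-out higher numbers stand for weaker inhibition and lower numbers for stronger inhibition), compound 1 gives 417 ug/mL. Compound 2 `O=C(CSc1nnnn1-c1ccccc1)N/N=c1/scc(-c2ccc(Cl)cc2)n1-c1ccccc1` gives 313 ug/mL, and the step of a 1.3-fold lower number from compound 1 to compound 2 (0.12 log units; within the scatter) stays within the scatter. Compound 3 `O=C(CSc1nnnn1-c1ccccc1)N/N=c1/scc(-c2ccc([N+](=O)[O-])cc2)n1-c1ccccc1` gives 14.3 ug/mL, a large step of a 29-fold lower number from compound 1 to compound 3 (1.46 log units; beyond the scatter) beyond the scatter. Compound 4 `Cc1nnc(SCC(=O)N/N=c2/scc(-c3ccccc3)n2-c2ccccc2)s1` differs from compound 1 in another part of the molecule: 5-methyl-1,3,4-thiadiazol-2-yl in place of 1-phenyl-1H-tetrazol-5-yl on a sulfur. Going by the values given here, both measured steps alter the aromatic ring where compounds 2 and 3 carry chloro and nitro, and leave the sulfur-bound group unchanged, so neither bears on this change; no measured step tests it. Without a guide, the expected step is a 1.0-fold lower number from compound 1 to compound 4 (0.02 log units; within the scatter), within the scatter. Compound 4 is therefore estimated at 400 ug/mL, between 150 ug/mL and 900 ug/mL.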

Compound 4, half-maximal inhibitory concentration: 197 ug/mL
Compound 4: middle estimate off by 2.0-fold (0.31 log units), on the high side; measured number inside the range.
By their numbers in this assay, from the lowest: compound 3; then compounds 4, 2 and 1 (each within the scatter of the next, the first and the last beyond it).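

The group on the sulfur turns out to matter in this assay: replacing 1-phenyl-1H-tetrazol-5-yl with the smaller 5-methyl-1,3,4-thiadiazol-2-yl gives a 2.1-fold lower number from compound 1 to compound 4 (0.33 log units; beyond the scatter). So far, only changes on the aromatic ring had been seen to move the number, and this modest step shows that a second part of the molecule can also do so. No measurement shown here explains the shift.

As far as these compounds go, this single swap changes the ring and removes the phenyl together, so their separate contributions remain unknown. Also open, from the compounds shown here alone, is how an amine in place of the methyl on the thiadiazole would behave.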